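A Fluorine Step Repeated on a Second Aryl Ring

A few compounds are considered here, and "the series" means these few. Any claim that something is new, unique, unknown or untested is made for them only; others in the source may bear on it.

Three compounds sharing one core were measured in an assay on mitochondria from L6 cells (Rattus norvegicus) for activation, with a stated time of 90 min; on this read-out lower numbers stand for an effect already at smaller amounts and higher numbers for an effect only at larger amounts of compound. Compound 1 `Oc1nc2nonc2nc1Nc1ccc(OCC(F)(F)F)cc1` gives 42300 nM in this assay. Compound 2 `Oc1nc2nonc2nc1Nc1ccc(OCC(F)(F)F)c(F)c1` gives 10400 nM. The change from compound 1 to compound 2, (fluoro in place of hydrogen on an aromatic carbon), produced a 4.1-fold lower number from compound 1 to compound 2 (0.61 log units; beyond the scatter). Compound 3 `Oc1nc2nonc2nc1Nc1cccc(C(F)(F)F)c1` gives 13300 nM in this assay; the difference between the core of compound 3 and that of compound 1 is not broken down here.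

Compound 4 `Oc1nc2nonc2nc1Nc1cc(C(F)(F)F)ccc1F` has not yet been measured. It differs from compound 3 by fluoro in place of hydrogen on an aromatic carbon. This is the same kind of change as that from compound 1 to compound 2, but the surroundings differ: in compound 2 the fluoro sits ortho to a 2,2,2-trifluoroethoxy group and meta to a large group, whereas in compound 4 it sits ortho to a large group and para to a trifluoromethyl group. Resting on the earlier step of a 4.1-fold lower number from compound 1 to compound 2 (0.61 log units; beyond the scatter) and on the value of compound 3 13300 nM, a smaller step is expected from compound 3 to compound 4, a 2.0-fold lower number from compound 3 to compound 4 (0.31 log units; beyond the scatter). Compound 4 is therefore estimated at 6500 nM in this assay, with a range from 2500 nM to 17000 nM.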

Compound 4, half-maximal effective concentration: 5100 nM
Compound 4: middle estimate off by 1.3-fold (0.11 log units), on the high side, and the stated range covers the measured number.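

In this assay, fluoro in place of hydrogen on an aromatic carbon gave a 2.6-fold lower number from compound 3 to compound 4 (0.42 log units; beyond the scatter) and so lowered the number on this second core as it had on the first. The two steps run in the same direction and cannot be told apart in size: the same change on two cores in this assay, a 4.1-fold lower number (0.61 log units; beyond the scatter) from compound 1 to compound 2 and a 2.6-fold lower number (0.42 log units; beyond the scatter) from compound 3 to compound 4, 1.6-fold (0.19 log units) apart, within the scatter of two such steps. This shows that the change carried over between these two cores in this assay, but two pairs give no rule for other cores, and the fluoro stands in different surroundings in each pair, so the part played by the core cannot be separated from that of the fluoro's place on the ring.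

The compounds shown leave open whether another group entering at the same carbon, such as chlorine, a methyl group or an amine, would shift the number in the same way. They also leave open what would follow if a nitrile or a longer chain stood where the trifluoromethyl group stands in compound 4.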